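The compounds below may be only part of what the source reports. "The series", "measured", "known", "first", "only" and "open" are said of these compounds alone.

Compound 3 `O=C(NOCc1ccccc1)c1cn(-c2ccccc2)nc1-c1ccc(Cl)cc1` gives 51900 nM in an ADME assay on HEK-293T cells (Homo sapiens) for antiproliferative activity, read by MTT assay, with a stated time of 48 h, in the presence of a further agent that is not named here (a higher number here means that more compound is tolerated, a lower number that less compound is tolerated), the second highest of three numbers; compound 2 `Cc1ccc(-c2nn(-c3ccccc3)cc2C(=O)NOCc2ccccc2)cc1` gives 40800 nM and compound 1 `O=C(NOCc1ccccc1)c1cn(-c2ccccc2)nc1-c1ccccc1` gives 122000 nM. The change to compound 4 `O=C(NOCc1ccccc1)c1cn(-c2ccccc2)nc1-c1ccc(F)cc1` is fluoro in place of chloro on an aromatic carbon. Among the compounds with values here, two measured steps bear on it: putting a chloro onto the unsubstituted ring gave a 2.4-fold lower number from compound 1 to compound 3 (0.37 log units; beyond the scatter), and a methyl on the same carbon gave a 3.0-fold lower number from compound 1 to compound 2 (0.48 log units; beyond the scatter), while the step between those two substituted rings was a 1.3-fold higher number from compound 2 to compound 3 (0.10 log units; within the scatter). Within the data shown here, no fluoro-bearing compound has been measured here, so compound 4 is expected to fall between compound 3 and compound 1. For compound 4 a step of a 1.3-fold higher number from compound 3 to compound 4 (0.13 log units; within the scatter) is expected, within the scatter. The estimate for compound 4 is 70000 nM, ranging from 35000 nM to 140000 nM.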

Compound 4, half-maximal cytotoxic concentration: 217000 nM
Estimate against measurement, compound 4: 3.1-fold (0.49 log units) below; measured number above the stated range.
By their numbers in this assay, from the lowest: compounds 2 and 3 (each within the scatter of the next); then compounds 1 and 4 (each within the scatter of the next).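

Chloro and methyl at this position do not behave like fluoro: replacing chloro with fluoro gives a 4.2-fold higher number from compound 3 to compound 4 (0.62 log units; beyond the scatter), and replacing methyl with fluoro gives a 5.3-fold higher number from compound 2 to compound 4 (0.73 log units; beyond the scatter). Against the unsubstituted ring, fluoro stays within the scatter, with a 1.8-fold higher number from compound 1 to compound 4 (0.25 log units; within the scatter), so among these compounds not every group on this carbon lowers the number in this assay. Nothing measured here accounts for the gap between the two halogens.

From the compounds shown here alone, whether bromo, methoxy or an amine on this carbon would sit nearer compound 3 or compound 4 remains open.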